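This account rests on a few compounds, and the source may have more. Where it says the series, first, only, none or still open, it means among the compounds named here.

Measured compounds:
compound 2 `C/N=C(/S)[C@@]1(c2cccnc2)CCCC[C@@H]1CCOC(C)=O`: 30 nM
compound 1 `C/N=C(/S)C1(c2cccnc2)CCCC/C1=C\COc1ccccc1`: 65 nM
compound 3 `C/N=C(/S)[C@@]1(c2cccnc2)CCCC[C@@H]1C/C=C/c1ccccc1`: 100 nM

In a functional assay (aorta) with Rattus norvegicus as the target (on this read-out lower numbers stand for stronger inhibition and higher numbers for weaker inhibition), compound 2 gives the lowest of the three numbers; the nearest is compound 1 with 65 nM, the furthest compound 3 with 100 nM, both gaps beyond the scatter. Compound 4 `C/N=C(/S)[C@@]1(c2cccnc2)CCCC[C@@H]1CCN1C(=O)COCC1=O` differs from compound 2 as follows: 3,5-dioxomorpholin-4-yl in place of acetoxy on a saturated chain carbon, two bonds along the chain from a saturated ring carbon. Among the compounds with values here, the one measured step at this side chain is a 3.3-fold higher number from compound 2 to compound 3 (0.52 log units; beyond the scatter), where the acetoxymethyl of compound 2 gave way to 2-phenylethenyl and the number rose modestly. Compound 1 carries a yet different chain and also sits higher than compound 2. Within the data shown here, no measured pair exchanges acetoxy for a cyclic imide-type group, so the step to compound 4 is not directly covered. Both departures from the acetoxy chain of compound 2 raised the number, so a modest rise is expected for compound 4 as well, a 2.3-fold higher number from compound 2 to compound 4 (0.37 log units; beyond the scatter). Compound 4 is estimated at 70 nM, with a range from 25 nM to 200 nM.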

Compound 4, concentration for 90% inhibition: 100 nM
Compound 4: middle estimate off by 1.4-fold (0.15 log units), on the low side, and the stated range covers the measured number.
By their numbers in this assay, from the lowest: compound 2; then compounds 1, 3 and 4 (each within the scatter of the next).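

On this saturated chain carbon, replacing acetoxy with 3,5-dioxomorpholin-4-yl, which brings in one six-membered non-aromatic ring, gives in this assay a 3.3-fold higher number from compound 2 to compound 4 (0.52 log units; beyond the scatter) and is a modest change. Compound 3 gives 100 nM and compound 4 gives 100 nM, so the chains of these two compounds, one ending in phenyl and the other in the dioxomorpholine ring, print the same number, and both stand above compound 2 at 30 nM. Nothing available on the compounds accounts for the rise from the acetoxy chain.

Open, as far as these compounds go, is whether a simple amine, a carboxylic acid or a plain hydroxyl at this place would stay close to compound 2. Also open, from the compounds shown here alone, is whether an open-chain amide would match the ring imide of compound 4.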